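The source may hold more compounds than are shown below. What is called first, only, known or untested is meant among the compounds shown, and "the series" means these compounds.

Measured compounds:
Compound 1, `CNc1nc(-c2ccccc2)nc2c1nnn2Cc1ccccc1F`, gives 25 nM in an assay on Cerebral cortex for displacement of a labelled ligand from adenosine receptor A1 (Bos taurus); on this read-out lower numbers stand for stronger inhibition and higher numbers for weaker inhibition.
Compound 2, `CCNc1nc(-c2ccccc2)nc2c1nnn2Cc1ccccc1`, gives 91 nM in this assay.

For the measured compounds named here, compound 2 holds the higher of the two numbers; compound 1 sits lower by a margin beyond the usual scatter, though the two structures differ in more than one place, so no single step connects them. Compound 3, `CCNc1nc(-c2ccccc2)nc2c1nnn2Cc1ccccc1F`, is compound 2 with one change: fluoro in place of hydrogen on an aromatic carbon. Going by the values given here, no measured pair isolates this change. Compound 1 carries the same fluoro on its benzyl group together with a methylamino group and gives 25 nM, which suggests the fluoro is compatible with a lower number. For compound 3 the expected step is a 1.8-fold lower number from compound 2 to compound 3 (0.26 log units; within the scatter). Compound 3 is estimated at 50 nM, between 20 nM and 130 nM.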

Compound 3, inhibition constant: 11 nM
Beside the measured number, compound 3's estimate is 4.5-fold (0.66 log units) above it; the measured number lies below the stated range.
By their numbers in this assay, from the lowest: compound 3; then compound 1; then compound 2.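

The 2-fluorobenzyl group, set against benzyl with everything else held fixed, gives an 8.3-fold lower number from compound 2 to compound 3 (0.92 log units; beyond the scatter) in this assay, so the fluoro on this aromatic carbon now has a step of its own, which the earlier pair could not provide. With the 2-fluorobenzyl group kept, the added methyl on the saturated chain carbon bound to the nitrogen gives a 2.3-fold lower number from compound 1 to compound 3 (0.36 log units; beyond the scatter) in the same read-out, so the amine chain is a second place where one small change moves the number beyond the scatter. The data shown hold no measurement that accounts for either step.

Going by these compounds, whether chloro or methoxy in place of the fluoro would behave alike, and whether the fluoro would do so elsewhere on the aromatic ring, stays open. So does the outcome of a longer chain such as propyl or butyl on the amine.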